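A few compounds are considered here, and "the series" means these few. Any claim that something is new, unique, unknown or untested is made for them only; others in the source may bear on it.

In an ADME assay on microsomes from liver (Rattus norvegicus) for metabolic stability (a lower number here means that the compound disappears faster, a higher number that the compound lasts longer), compound 1 `CC(C)C(Nc1nnc[nH]1)c1ccc(-c2ccc3cccc(F)c3c2)[nH]c1=O` gives 1.29 h. Compound 3 `CC(C)[C@H](C[C@H]1CCNC1=O)c1ccc(-c2ccc3cccc(F)c3c2)[nH]c1=O` gives 0.227 h, so compound 1 holds the higher of these two exact numbers, and the gap lies beyond the usual scatter. Compound 2 `CCn1ncc2c(F)cc(-c3ccc(C(CC)(CC)c4nnc[nH]4)c(=O)[nH]3)cc21` reads > 3 h, which is a limit of the assay and not a number.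

Compound 4 `CC(C)C(c1nnc[nH]1)c1ccc(-c2ccc3cccc(F)c3c2)[nH]c1=O` is still unmeasured. It has 4H-1,2,4-triazol-3-yl in place of (4H-1,2,4-triazol-3-yl)amino on a saturated chain carbon bound to an aromatic carbon and a saturated chain carbon. Within the data shown here, no measured pair shows this change, so no step beyond the scatter is expected in this assay. The estimated step is a 1.2-fold higher number from compound 1 to compound 4 (0.09 log units; within the scatter). The half-life expected for compound 4 is 1.6 h, with a range of 0.7 h to 3 h.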

Compound 4, half-life: 0.552 h
The estimate for compound 4 lay 2.9-fold (0.46 log units) above the measured number; the measured number lies below the stated range.
By their numbers in this assay, from the lowest: compound 3; then compound 4; then compound 1. At a limit, above all of these: compound 2.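

Swapping (4H-1,2,4-triazol-3-yl)amino for 4H-1,2,4-triazol-3-yl on a saturated chain carbon bound to an aromatic carbon and a saturated chain carbon gives, in this assay, a 2.3-fold lower number from compound 1 to compound 4 (0.37 log units; beyond the scatter). This single-place pair shows that the half-life responds to a small edit at this position, with the shorter half-life on the side of the directly attached triazole. Nothing measured here bears on why the half-life shifts.

Still open, going by these compounds, is how a simple amine or a carboxylic acid at this position would compare. On these data alone, whether the same swap has the same effect on a different core is also open.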